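Swapping the methylphenyl of compound 1 for a chlorophenyl

A few compounds are considered here, and "the series" means these few. Any claim that something is new, unique, unknown or untested is made for them only; others in the source may bear on it.

Going by the values given here, compound 1 `Cc1ccc(/C=C/C(=O)c2ccc(Nc3cc(C)nc4nc(SCc5nc6ccccc6[nH]5)nn34)cc2)cc1` is tested in a functional assay on SW-620 cells (Homo sapiens) for cytotoxicity, read by MTT assay, with stated times of 4 h and 72 h, tested at 2 uM (on this read-out lower numbers stand for stronger inhibition and higher numbers for weaker inhibition), where compound 1 gives 1520 nM, the highest of the three numbers measured so far. Compound 2 `Cc1cc(Nc2ccc(C(=O)/C=C/c3ccc(-n4cccn4)cc3)cc2)n2nc(SCc3nc4ccccc4[nH]3)nc2n1` gives 340 nM and compound 3 `Cc1cc(Nc2ccc(C(=O)/C=C/c3ccc(Br)cc3)cc2)n2nc(SCc3nc4ccccc4[nH]3)nc2n1` gives 290 nM; these two lie within the scatter of each other. Compound 4 `Cc1cc(Nc2ccc(C(=O)/C=C/c3cccc(Cl)c3)cc2)n2nc(SCc3nc4ccccc4[nH]3)nc2n1` has not yet been measured; it differs from compound 1 by 3-chlorophenyl in place of 4-methylphenyl on a double-bonded chain carbon bound to a double-bonded chain carbon. Among the compounds with values here, two measured steps bear on this change, since each also replaces the methyl of compound 1: a 4.5-fold lower number from compound 1 to compound 2 (0.65 log units; beyond the scatter) and a 5.2-fold lower number from compound 1 to compound 3 (0.72 log units; beyond the scatter). Both lowered the number modestly. Within the data shown here, a lowering is therefore expected as well, a 3.0-fold lower number from compound 1 to compound 4 (0.48 log units; beyond the scatter), though no measured step places a chloro on that ring, so the range is kept wide. Compound 4 is expected to give 500 nM, between 200 nM and 1400 nM.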

Compound 4, half-maximal inhibitory concentration: 400 nM
Beside the measured number, compound 4's estimate is 1.3-fold (0.10 log units) above it, within the range that was stated.
By their numbers in this assay, from the lowest: compounds 3, 2 and 4 (each within the scatter of the next); then compound 1.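

Replacing 4-methylphenyl with 3-chlorophenyl gives a 3.8-fold lower number from compound 1 to compound 4 (0.58 log units; beyond the scatter) so the lowering seen earlier also holds for a phenyl group that carries its new substituent at 3 rather than at 4. With a 1.4-fold higher number from compound 3 to compound 4 (0.14 log units; within the scatter) and a 1.2-fold higher number from compound 2 to compound 4 (0.07 log units; within the scatter) the three replacements cannot be told apart. No evidence is available that explains these steps.

The compounds shown leave open whether 4-chlorophenyl would match 3-chlorophenyl. They also leave open whether an amine or a carboxylic acid on this phenyl would keep the lower number.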